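This account rests on a few compounds, and the source may have more. Where it says the series, first, only, none or still open, it means among the compounds named here.

Notes on the series in a functional assay on A549 cells (Homo sapiens) for antiproliferative activity, read by sulforhodamine B assay, with a stated time of 48 h; on this read-out higher numbers stand for weaker inhibition of growth and lower numbers for stronger inhibition of growth. Three compounds have numbers. Compound 1 `CCCCCCCCCCn1cc(Cn2c(CC)nc3nc(C(F)(F)F)ccc3c2=O)nn1` gives 860 nM. Compound 2 `O=C(Cn1cc(COc2nc(-c3ccccc3)nc3nc(C(F)(F)F)ccc23)nn1)Nc1ccccc1` gives 140 nM. Compound 3 `CCCCCCCCCCn1cc(COc2nc(-c3ccccc3)nc3nc(C(F)(F)F)ccc23)nn1` gives 2310 nM, the highest of the three; compound 1 sits nearest to it and compound 2 furthest, both gaps beyond the scatter. Among the measured compounds shown here, the one single-point step available runs a 17-fold higher number from compound 2 to compound 3 (1.22 log units; beyond the scatter), so trading an aromatic amide-bearing substituent on the triazole for a plain chain cost a large amount in this assay.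

Compound 4 `COc1cc(-n2cc(COc3nc(-c4ccccc4)nc4nc(C(F)(F)F)ccc34)nn2)cc(OC)c1OC` is the next member. The change from compound 3 is 3,4,5-trimethoxyphenyl in place of decyl on an aromatic nitrogen. This is not the reverse of the measured step, yet it points the same way: the chain leaves and an aromatic group with three acceptors enters at the triazole. On that basis a move toward the lower numbers, of the order seen in the step from compound 2 to compound 3 but not necessarily its full size, is expected. The estimated step is a 7.7-fold lower number from compound 3 to compound 4 (0.89 log units; beyond the scatter). Compound 4 is therefore expected to give about 300 nM, with a range from 70 nM to 1500 nM.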

Compound 4, concentration for 50% growth inhibition: 4050 nM
The estimate for compound 4 lay 14-fold (1.13 log units) below the measured number; measured number outside the range, above it.
By their numbers in this assay, from the lowest: compound 2; then compound 1; then compounds 3 and 4 (each within the scatter of the next).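

In this assay, putting 3,4,5-trimethoxyphenyl in place of decyl on an aromatic nitrogen of the five-membered aromatic ring gives a 1.8-fold higher number from compound 3 to compound 4 (0.24 log units; within the scatter) and so does not separate the two compounds, even though a long saturated chain gives way to an aromatic ring with hydrogen-bond acceptors. The (phenylcarbamoyl)methyl group of compound 2 stands apart at the same place, with a 29-fold higher number from compound 2 to compound 4 (1.46 log units; beyond the scatter) in the same assay. The large step seen earlier against decyl therefore cannot be read as a simple contrast between a chain and an aromatic ring, and among compound 2, compound 3 and compound 4 only compound 2 reaches the low numbers. Nothing in hand gives a reason for these numbers.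

Still open, going by these compounds, is which part of (phenylcarbamoyl)methyl carries the difference: the carbonyl, the amide hydrogen, the terminal phenyl or the saturated carbon that links it to the ring, which a plain benzyl, an unsubstituted acetamide or a carboxylic acid at this nitrogen could help to separate. Also open, on these data alone, is whether the same order holds on the core of compound 1.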